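Acetyl in Place of Hydrogen on the Core of Compound 3

The source may hold more compounds than are shown below. What is called first, only, known or untested is meant among the compounds shown, and "the series" means these compounds.

Compound 3, `Nc1ncnc2c1ccn2-c1ccc(NC(=O)c2ccc(Cl)c(C(F)(F)F)c2)cc1`, carries a free amino group on its core and an amide link from the outer ring to a chlorinated, trifluoromethyl-bearing benzoyl. In a functional assay on A375P cells (Homo sapiens) for antiproliferative activity, read by MTT assay, with a stated time of 24 h (a higher number here means a weaker inhibitor, a lower number a stronger inhibitor), compound 3 gives 2900 nM. Compound 1, `O=C(Nc1ccc(-n2ccc3c(NC(=O)c4ccccc4)ncnc32)cc1)c1ccc(Cl)c(C(F)(F)F)c1`, differs only in that the same nitrogen carries a benzoyl group, and in this assay compound 1 gives 2300 nM. Of the two numbers on record, compound 3 holds one and compound 1 the other, and a 1.3-fold higher number from compound 1 to compound 3 (0.10 log units; within the scatter) puts the pair within the scatter of each other. Compound 2, `CC(=O)Nc1ncnc2c1ccn2-c1ccc(NC(=O)Nc2cccc(Cl)c2Cl)cc1`, is the third member: it bears an acetyl on that nitrogen but a urea in place of the amide and a differently substituted outer ring. In this assay compound 2 gives only a limit, > 10000 nM, which is the limit of > 10000 nM in this assay, at which 1 of the 3 values shown sits.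

Compound 4, `CC(=O)Nc1ncnc2c1ccn2-c1ccc(NC(=O)c2ccc(Cl)c(C(F)(F)F)c2)cc1`, arises from compound 3 through (acetyl in place of hydrogen on a nitrogen on an aromatic ring). Within the data shown here, the only measured step on this nitrogen is a 1.3-fold higher number from compound 1 to compound 3 (0.10 log units; within the scatter), where a larger acyl group was exchanged for hydrogen and the number moved no further than the scatter. The acetyl of compound 4 is smaller than that benzoyl, and compound 2, which also carries it, supplies no number to compare. One therefore expects a 1.0-fold higher number from compound 3 to compound 4 (0.01 log units; within the scatter), that is, no shift beyond the scatter. Compound 4 is accordingly estimated at 3000 nM, with a range from 1200 nM to 8000 nM.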

Compound 4, half-maximal inhibitory concentration: > 10000 nM
Compound 4 gave a limit, no number; the forecaster's own chance of this, stated with the estimate: 20%; middle value at least 3.3-fold (0.52 log units) away from the limit.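

Among these compounds, on this nitrogen, acylation is no longer neutral: in this assay, acetyl in place of hydrogen gives an at least 3.4-fold higher number from compound 3 to compound 4 (0.53 log units; beyond the scatter), whereas the only earlier step here, with hydrogen in place of benzoyl, gave a 1.3-fold higher number from compound 1 to compound 3 (0.10 log units; within the scatter). The identity of the acyl group therefore matters, not merely its presence, as methyl in place of phenyl on the same carbonyl carbon gives an at least 4.3-fold higher number from compound 1 to compound 4 (0.63 log units; beyond the scatter), so the smaller acetyl, not the larger benzoyl, is the group that separates from the free amino compound. The result for compound 4 is a limit and not a number, so the true size of both steps stays unknown, and compound 4 now sits with compound 2 at that limit: the limit of > 10000 nM in this assay, at which 2 of the 4 values shown sit.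

The step between compound 2 and compound 4 cannot be read, as both give only limits, so these compounds say nothing about how the urea and the amide compare when acetyl sits on this nitrogen. As far as these compounds go, it also remains open how a propanoyl or a cyclopropanecarbonyl group on this nitrogen would behave, or a simple methyl with no carbonyl at all, and so whether the loss belongs to acetyl alone.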